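The source may hold more compounds than are shown below. What is called first, only, known or untested is meant among the compounds shown, and "the series" means these compounds.

Series notes. Compound 1 `NS(=O)(=O)CSc1nnc(Br)n1Cc1ccc(Br)c2ccccc12` carries an unsubstituted sulfonamide nitrogen; in an assay on HEK293 cells for inhibition of solute carrier family 22 member 12 (Homo sapiens) (on this read-out lower numbers stand for stronger inhibition and higher numbers for weaker inhibition), compound 1 gives 365000 nM. Compound 2 `O=S(=O)(CSc1nnc(Br)n1Cc1ccc(Br)c2ccccc12)Nc1ccc(Cl)nc1` gives 1940 nM and compound 3 `O=S(=O)(CSc1nnc(Br)n1Cc1ccc(Br)c2ccccc12)Nc1ccc(F)nc1` gives 1550 nM. Compound 3 shows the lowest number of the three: the nearest step is a 1.3-fold lower number from compound 2 to compound 3 (0.10 log units; within the scatter), within the scatter, the widest is a 240-fold lower number from compound 1 to compound 3 (2.37 log units; beyond the scatter). Compound 4 `O=S(=O)(CSc1nnc(Br)n1Cc1ccc(Br)c2ccccc12)Nc1cc(Cl)cnc1Cl` differs from compound 3 by 2,5-dichloropyridin-3-yl in place of 6-fluoropyridin-3-yl on a sulfonamide nitrogen. The steps of a 190-fold lower number from compound 1 to compound 2 (2.27 log units; beyond the scatter) and a 240-fold lower number from compound 1 to compound 3 (2.37 log units; beyond the scatter) show that an aryl group on this nitrogen carries the whole gain, while the halogen swap a 1.3-fold lower number from compound 2 to compound 3 (0.10 log units; within the scatter) stayed within the scatter. Within the data shown here, no measured pair covers a changed substituent pattern on the pyridinyl group, so in this assay no step beyond the scatter is expected; compound 4 is estimated at 2000 nM, range 700 nM to 6000 nM, meaning an expected step of a 1.3-fold higher number from compound 3 to compound 4 (0.11 log units; within the scatter).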

Compound 4, half-maximal inhibitory concentration: 2790 nM
Compound 4: middle estimate off by 1.4-fold (0.14 log units), on the low side, within the range that was stated.
By their numbers in this assay, from the lowest: compounds 3, 2 and 4 (each within the scatter of the next); then compound 1.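

In this assay the step of a 1.8-fold higher number from compound 3 to compound 4 (0.26 log units; within the scatter) and the step of a 1.4-fold higher number from compound 2 to compound 4 (0.16 log units; within the scatter) both stay within the scatter, so on the sulfonamide nitrogen 2,5-dichloropyridin-3-yl is not told apart from 6-fluoropyridin-3-yl or 6-chloropyridin-3-yl. Among these compounds, the step of a 130-fold lower number from compound 1 to compound 4 (2.12 log units; beyond the scatter) shows that the large gain over the unsubstituted sulfonamide holds with a changed substituent pattern on the pyridinyl group, which the earlier compounds could not show. No evidence bearing on this result is available.

On these data alone, whether the gain needs the ring nitrogen or the halogens stays open, and a plain phenyl or unsubstituted pyridin-3-yl group on this nitrogen would address that. Also open, as far as these compounds go, is how a carboxylic acid or an amine on the pyridinyl group would read.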